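Phenyl for Methoxypyridinylmethyl on the Ring Amide Nitrogen

The compounds below may be only part of what the source reports. "The series", "measured", "known", "first", "only" and "open" are said of these compounds alone.

Compound 1 `COc1ccc2[nH]c(C(=O)N3CC(=O)N(Cc4ccccc4)[C@@H](CCc4ccccc4)C3)cc2c1` gives > 30000 nM in an ADME assay on Vero cells (Chlorocebus sabaeus) for cytotoxicity, with a stated time of 7 days (on this read-out higher numbers stand for lower toxicity in this test and lower numbers for higher toxicity in this test), which is a limit of the assay rather than a number.
Compound 2 `O=C(c1cc2cc(C3CC3)ccc2[nH]1)N1CC(=O)N(Cc2ccccc2)[C@@H](CN2CCN(Cc3ccccc3)CC2)C1` gives 5500 nM in this assay.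
Compound 3 `COc1ccc2[nH]c(C(=O)N3CC(=O)N(Cc4cccc(OC)n4)[C@@H](Cc4ccccc4)C3)cc2c1` gives > 30000 nM in this assay, again only a limit.

Compound 3 thus stands at the limit of > 30000 nM in this assay, at which 2 of the 3 values shown sit, and only compound 2 yields an actual number in this assay. Compound 4 `COc1ccc2[nH]c(C(=O)N3CC(=O)N(c4ccccc4)[C@@H](Cc4ccccc4)C3)cc2c1` differs from compound 3 by phenyl in place of (6-methoxypyridin-2-yl)methyl on an amide-type nitrogen in a ring. Within the data shown here, no step between measured compounds is available, so the change is judged on the three values alone. The step of an at least 1.2-fold lower number from compound 3 to compound 4 (0.07 log units; that floor lies within the scatter) is expected to stay within the scatter, with no clear direction. Compound 4 is estimated at 25000 nM in this assay, most likely between 8000 nM and 60000 nM.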

Compound 4, half-maximal cytotoxic concentration: > 30000 nM
Compound 4 was reported as a limit (the forecaster's own chance of this, stated with the estimate: 55%); at least 1.2-fold (0.07 log units) between middle value and limit.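

Among these compounds, compound 3 and compound 4 both give only a limit in this assay, so no step between them can be read. Going by these compounds, whether phenyl in place of (6-methoxypyridin-2-yl)methyl changes the read-out in this assay at all stays open.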